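Working notes: the group on the amine nitrogen

The source may report more compounds than this note shows. Statements on the series, on what has been measured and on what is new or still open speak of the compounds shown alone.

Measured in a functional assay (mast cells) for inhibition, with Rattus norvegicus as the target; a higher number here means that more compound is needed for the effect, a lower number that less compound is needed:
- compound 1 `CC1CC/C(=N\Nc2ccccc2F)c2ncc(C(=O)O)c(=O)n21`: 1200 nM
- compound 2 `CC1CC/C(=N\Nc2ccc(Br)cc2)c2ncc(C(=O)O)c(=O)n21`: 2000 nM

Among the compounds with values here, compound 2 does not separate from compound 1, as the only measured step is a 1.7-fold higher number from compound 1 to compound 2 (0.22 log units; within the scatter). Next is compound 3 `CC1CC/C(=N\Nc2ccccc2O)c2ncc(C(=O)O)c(=O)n21`, still unmeasured, where the change is 2-hydroxyphenyl in place of 4-bromophenyl on an amine nitrogen. It puts 2-hydroxyphenyl in place of 4-bromophenyl on an amine nitrogen. Within the data shown here, the measured step exchanged the group at this same place and stayed small, though no compound with a 2-hydroxyphenyl group has a value yet. Expected in this assay is a 1.3-fold lower number from compound 2 to compound 3 (0.12 log units; within the scatter), so no step beyond the scatter is anticipated. For compound 3 the estimated value is 1500 nM, with an expected range of 500 nM to 4500 nM.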

Compound 3, half-maximal effective concentration: 208000 nM
For compound 3 the middle estimate is 140-fold (2.14 log units) below the measured one; the whole stated range lies below it.
By their numbers in this assay, from the lowest: compounds 1 and 2 (each within the scatter of the next); then compound 3.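

The group on the amine nitrogen is less forgiving than compounds 1 and 2 alone suggested: in this assay, 2-hydroxyphenyl in place of 4-bromophenyl gives a 100-fold higher number from compound 2 to compound 3 (2.02 log units; beyond the scatter). Hydroxy in place of fluoro on an aromatic carbon is enough on its own for a large step, with a 170-fold higher number from compound 1 to compound 3 (2.24 log units; beyond the scatter). No measurement at hand bears on the reason for this step. From the compounds shown here alone, it remains open whether a 2-methoxyphenyl or 2-aminophenyl group would stay with compounds 1 and 2 or fall with compound 3.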